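The compounds below may be only part of what the source reports. "The series", "measured", "known", "first", "only" and "open" are said of these compounds alone.

Compound 1: `CN(c1ccc2cc(NC(=O)CCc3ccc(C(F)(F)F)cc3)ccc2n1)C1CCCCC1`, 18 nM
Compound 2: `CC1CCCN1c1ccc2cc(NC(=O)CCc3ccc(C(F)(F)F)cc3)ccc2n1`, 5 nM
Compound 3: `CC(C)C(=O)NC1CCN(c2ccc3cc(NC(=O)CCc4ccc(C(F)(F)F)cc4)ccc3n2)C1`, not yet measured

All numbers come from an assay on isolated protein for displacement of a labelled ligand from melanin-concentrating hormone receptor 1 (Homo sapiens); on this read-out lower numbers stand for stronger inhibition and higher numbers for weaker inhibition. Compound 1 gives 18 nM in this assay, while compound 2 gives 5 nM. Among the compounds with values here, the one measured step, a 3.6-fold lower number from compound 1 to compound 2 (0.56 log units; beyond the scatter), leaves compound 2 with the lowest of the two numbers so far; compound 1 is its only neighbour, and the gap to it lies beyond the scatter.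

Compound 3 follows from compound 2 by 3-((isopropylcarbonyl)amino)pyrrolidin-1-yl in place of 2-methylpyrrolidin-1-yl on an aromatic carbon. Within the data shown here, the only step recorded at this place on the shared core is a 3.6-fold lower number from compound 1 to compound 2 (0.56 log units; beyond the scatter), which exchanged one amine for another; neither measured compound carries the group that enters here, so nothing bears on it directly. From the compounds shown here alone, both measured amines at this place gave low numbers, and the entering group keeps a five-membered ring of the same kind, but the added portion is untested. The account therefore expects a modest rise in this assay, a 4.0-fold higher number from compound 2 to compound 3 (0.60 log units; beyond the scatter), with wide uncertainty. Compound 3 is estimated at 20 nM, within a range of 4 nM to 100 nM.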

Compound 3, half-maximal inhibitory concentration: 1 nM
Beside the measured number, compound 3's estimate is 20-fold (1.30 log units) above it, outside the stated range (below it).
By their numbers in this assay, from the lowest: compound 3; then compound 2; then compound 1.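

At this place, an aromatic carbon next to the ring nitrogen, the shared core accepts a much larger group than compound 2 carries: in this assay, 3-((isopropylcarbonyl)amino)pyrrolidin-1-yl, with 11 heavy atoms against 6 for 2-methylpyrrolidin-1-yl, gives a 5.0-fold lower number from compound 2 to compound 3 (0.70 log units; beyond the scatter) and, measured against the cyclohexyl(methyl)amino group, an 18-fold lower number from compound 1 to compound 3 (1.26 log units; beyond the scatter) and so stands beyond the scatter from both earlier compounds. The entering group brings 1 hydrogen-bond donor and 2 hydrogen-bond acceptors where 2-methylpyrrolidin-1-yl has 0 and 1, so this place does not require a group free of donors. Nothing measured here explains why the number falls with this change.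

The step from compound 2 to compound 3 removes the ring methyl and adds the isopropylcarbonyl amide at once, so the compounds shown do not separate the share of each change. From the compounds shown here alone, it also remains open how the number would respond to a free amine such as 3-aminopyrrolidin-1-yl, to a shorter acetyl amide or to a longer acyl chain on the same ring.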